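Chloro in Place of Methoxy: An Expected Antiproliferative Read-Out

The source may report more compounds than this note shows. Statements on the series, on what has been measured and on what is new or still open speak of the compounds shown alone.

Measured compounds:
compound 1 `COc1ccc(-c2nc(SCC(=O)c3sc(-c4ccccc4)nc3C)nc(N)c2C#N)cc1`: 60.8%
compound 2 `COc1ccc(-c2nc(C)c(C(=O)CSc3nc(-c4cccc(OC)c4)c(C#N)c(=O)[nH]3)s2)cc1`: 66.7%

In a functional assay on U-87MG ATCC cells for antiproliferative activity against U-87 MG (Homo sapiens), read by MTT assay, with a stated time of 48 h, tested at 10 uM (a lower number here means a stronger effect, a higher number a weaker effect of the compound at the concentration tested), compound 1 gives 60.8%. Compound 2 gives 66.7% in this assay, and the two numbers lie within the scatter of each other, so neither compound can be set apart from the other on these data. Among the measured compounds shown here, compound 2 also differs from compound 1 in more than one place, so it offers no single step that could be followed.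

Compound 3 `Cc1nc(-c2ccccc2)sc1C(=O)CSc1nc(N)c(C#N)c(-c2ccc(Cl)cc2)n1` differs from compound 1 in one place: chloro in place of methoxy on an aromatic carbon. For the measured compounds named here, no step between measured compounds bears on this change, so there is nothing to size it by. Compound 3 is therefore expected to stay close to compound 1, with a step of a number 2.8 percentage points lower from compound 1 to compound 3 (within the scatter) that is not expected to go beyond the scatter in either direction. In this assay compound 3 is estimated at 58%, between 40% and 76%.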

Compound 3, a percentage reported as activity, at one concentration (the size of the read-out at that concentration, not a potency): 58.8%
For compound 3 the middle estimate is 0.8 percentage points below the measured one, and the stated range covers the measured number.
By their numbers in this assay, from the lowest: compounds 3, 1 and 2 (each within the scatter of the next).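

Chloro in place of methoxy on this aromatic carbon, para to a large group, gives a number 2 percentage points lower from compound 1 to compound 3 (within the scatter) in this assay and so provides the first measured step at this position. The 4-methoxyphenyl and 4-chlorophenyl compounds cannot be told apart at the one concentration tested, even though the exchange replaces two heavy atoms with one and takes away a hydrogen-bond acceptor. No measurement at hand accounts for this similarity.

On these data alone, it remains open whether an amine, a carboxylic acid or a longer chain such as butoxy on the same aromatic carbon would give a step beyond the scatter. Also open, as far as these compounds go, is whether chloro in place of methoxy would read the same on the core of compound 2, which differs from compound 1 in more than one place.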